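This account rests on a few compounds, and the source may have more. Where it says the series, first, only, none or still open, it means among the compounds named here.

Compound 1 `O=C(Nc1ccccc1)c1csc(Cc2c(Cl)cccc2Cl)n1` gives > 4000 nM in an assay on CHO cells, read by calcium flux (a higher number here means a weaker inhibitor, a lower number a stronger inhibitor), a limit of the assay.
Compound 2 `COc1ccc(NC(=O)c2csc(Cc3c(Cl)cccc3Cl)n2)cc1` gives > 4000 nM in this assay, again a limit.
Compound 3 `N#Cc1ccc(NC(=O)c2csc(Cc3c(Cl)cccc3Cl)n2)cc1` gives 450 nM in this assay.

Among the compounds with values here, compound 3 carries the only true number here; the other two values are limits (the limit of > 4000 nM in this assay, at which 2 of the 3 values shown sit). Compound 4 `O=C(Nc1ccccc1Br)c1csc(Cc2c(Cl)cccc2Cl)n1` differs from compound 3 by 2-bromophenyl in place of 4-cyanophenyl on an amide-type nitrogen. Within the data shown here, the steps that bear on this are an at least 8.8-fold lower number from compound 1 to compound 3 (0.94 log units; beyond the scatter) and an at least 8.8-fold lower number from compound 2 to compound 3 (0.94 log units; beyond the scatter), both showing that the cyano group goes with a lower number. Compound 4 lacks that cyano and instead carries a 2-bromophenyl, so the step is expected to run the other way, towards the limit. Compound 4 is therefore expected to give 4000 nM in this assay, within 1000 nM to 16000 nM, which means an expected step of an 8.9-fold higher number from compound 3 to compound 4 (0.95 log units; beyond the scatter).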

Compound 4, half-maximal inhibitory concentration: > 4000 nM
Compound 4 was reported as a limit; the forecaster's own chance of this, stated with the estimate: 55%; the middle value lies on the limit itself.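

In this assay, 2-bromophenyl in place of 4-cyanophenyl on the amide-type nitrogen gives an at least 8.8-fold higher number from compound 3 to compound 4 (0.94 log units; beyond the scatter). A halogen on the phenyl therefore does not match the nitrile here, and among hydrogen, methoxy, bromo and cyano, only compound 3 gives a true number. The other steps to compound 4 cannot be read because both compounds in each pair sit at the same limit: the limit of > 4000 nM in this assay, at which 3 of the 4 values shown sit.

Compound 4 differs from compound 3 in both the group and its place on the phenyl, so the contribution of each remains unseparated. As far as these compounds go, it also remains open whether an amine or a carboxylic acid in place of the nitrile would give a true number.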